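Nitro in Place of Bromo on the Ketone Ring

This account rests on a few compounds, and the source may have more. Where it says the series, first, only, none or still open, it means among the compounds named here.

Measured so far in a functional assay on HepG2 cells (Homo sapiens) for inhibition, read by MTT assay, with a stated time of 48 h, tested at 10 uM; a higher number here means more inhibition of growth at the concentration tested, a lower number less inhibition of growth:
- compound 1 `O=C(/C=C/c1ccc(OCc2cn(Cc3cccc(Br)c3)nn2)cc1)c1ccc(Br)cc1`: 25%
- compound 2 `O=C(/C=C/c1ccc(OCc2cn(Cc3ccccc3F)nn2)cc1)c1ccc(Br)cc1`: 29%
- compound 3 `O=C(/C=C/c1ccc(OCc2cn(Cc3ccc(F)cc3)nn2)cc1)c1ccc(Br)cc1`: 22%

Compound 1 sits in the middle of these three numbers, yet all three lie within the usual scatter of one another: the step of a number 3 percentage points lower from compound 1 to compound 3 (within the scatter) and the step of a number 4 percentage points higher from compound 1 to compound 2 (within the scatter) are both too small to count, as is the step of a number 7 percentage points lower from compound 2 to compound 3 (within the scatter).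

Compound 4 `O=C(/C=C/c1ccc(OCc2cn(Cc3cccc(Br)c3)nn2)cc1)c1ccc([N+](=O)[O-])cc1` differs from compound 1 in one place: nitro in place of bromo on an aromatic carbon. For the measured compounds named here, none of the measured steps touches this part of the molecule; all three concern the benzyl group on the saturated chain carbon bound to the aromatic nitrogen at the other end of the shared core, and all stayed within the scatter. There is therefore no measured guide to this change, only the observation that single-group swaps in this series have so far not moved the number.

For compound 4 the expected result in this assay is a step of a number 3 percentage points higher from compound 1 to compound 4 (within the scatter), that is, no change beyond the scatter. The estimate for compound 4 is 28%, with a range from 10% to 48%.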

Compound 4, percent growth inhibition at one concentration: 13%
Beside the measured number, compound 4's estimate is 15 percentage points above it, within the range that was stated.
By their numbers in this assay, from the lowest: compounds 4, 3, 1 and 2 (each within the scatter of the next, the first and the last beyond it).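

In this assay, the swap of 4-bromophenyl to 4-nitrophenyl gives a number 12 percentage points lower from compound 1 to compound 4 (beyond the scatter), a modest step but one that goes beyond the scatter. For the compounds shown here, the earlier steps, all within the benzyl group at the other end of the shared core, stayed within the scatter, so this position on the ring bearing the carbonyl is the first place where a single swap clearly moves the number. Nothing measured here explains the lower growth inhibition seen with nitro.

The compounds shown leave open whether other groups on this same aromatic carbon, such as an amine, a methoxy group or a carboxylic acid, would lower the number as well, keep it level or raise it. They also leave open whether nitro in place of bromo would give a similar step with the 2-fluorophenyl and 4-fluorophenyl groups of compound 2 and compound 3.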